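The source may hold more compounds than are shown below. What is called first, only, known or untested is meant among the compounds shown, and "the series" means these compounds.

Compound 1 `Cn1ncc(Cl)c1-c1cc(C(=O)N[C@@H]2CN[C@H](CC(O)CO)C[C@H]2c2ccc(Cl)c(Cl)c2)oc1Cl` is the starting point. In a functional assay on LNCaP cells (Homo sapiens) for antiproliferative activity (a higher number here means a weaker inhibitor, a lower number a stronger inhibitor), compound 1 gives 70 nM, the second highest of three numbers: compound 2 `Cn1ncc(Cl)c1-c1cc(C(=O)N[C@@H]2CN[C@H](CCn3cncn3)C[C@H]2c2ccc(Cl)c(Cl)c2)oc1Cl` gives 60 nM, and a 1.2-fold lower number from compound 1 to compound 2 (0.07 log units; within the scatter); compound 3 `CN(C)CC[C@@H]1C[C@@H](c2ccc(Cl)c(Cl)c2)[C@H](NC(=O)c2cc(-c3c(Cl)cnn3C)c(Cl)o2)CN1` gives 1930 nM, and a 28-fold higher number from compound 1 to compound 3 (1.44 log units; beyond the scatter). Compound 4 `Cn1ncc(Cl)c1-c1cc(C(=O)N[C@@H]2CN[C@H](CCO)C[C@H]2c2ccc(Cl)c(Cl)c2)oc1Cl` differs from compound 1 by hydrogen in place of hydroxymethyl on a saturated chain carbon bound to an oxygen on a saturated carbon and a saturated chain carbon. Among the measured compounds shown here, no measured step removes a hydroxymethyl on its own; the two steps from compound 1 exchange the whole side group, and only the swap to a dimethylamino group moved the number far. Keeping a hydroxyl on the chain, the step is expected to stay within the scatter: for compound 4 the expected value is 100 nM, between 40 nM and 300 nM, so that a 1.4-fold higher number from compound 1 to compound 4 (0.15 log units; within the scatter) is expected.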

Compound 4, half-maximal inhibitory concentration: 160 nM
The estimate for compound 4 lay 1.6-fold (0.20 log units) below the measured number; the range from low to high includes it.
By their numbers in this assay, from the lowest: compounds 2 and 1 (each within the scatter of the next); then compound 4; then compound 3.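

In this assay, going from 2,3-dihydroxypropyl to 2-hydroxyethyl gives a 2.3-fold higher number from compound 1 to compound 4 (0.36 log units; beyond the scatter), so removing hydroxymethyl alone has a modest but real cost. The other comparisons place this chain among its neighbours: against the triazole there is a 2.7-fold higher number from compound 2 to compound 4 (0.43 log units; beyond the scatter), while against dimethylamino there is a 12-fold lower number from compound 3 to compound 4 (1.08 log units; beyond the scatter), so hydroxy retains far more activity than dimethylamino. No measurement offered here explains these shifts. Still open, on these data alone, is how a primary amine or a carboxylic acid in place of the hydroxy group would compare, and whether a longer chain carrying one hydroxy group would match compound 1.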